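This account rests on a few compounds, and the source may have more. Where it says the series, first, only, none or still open, it means among the compounds named here.

Compound 3 `Cc1c(Cc2ccc(Br)cc2)c(=O)oc2cc(OCC(O)CN3CCC(C(N)=O)CC3)ccc12` was run in an ADME assay on A549 cells (Homo sapiens) for cytotoxicity, read by CellTiter-Glo; on this read-out higher numbers stand for lower toxicity in this test and lower numbers for higher toxicity in this test. Compound 3 gives > 100000 nM, a limit of the assay rather than a number. Compound 1 `Cc1c(Cc2ccccc2)c(=O)oc2cc(OCC(O)CNCc3ccccc3)ccc12` gives > 100000 nM, again a limit. For the measured compounds named here, compound 2 `Cc1c(Cc2ccccc2)c(=O)oc2cc(OCC(O)CNCCCCCCO)ccc12` gives 40300 nM; the only counted step, an at least 2.4-fold lower number from compound 1 to compound 2 (0.39 log units; beyond the scatter), concerns a chain on the amine nitrogen and not the aromatic ring. Compound 4 `Cc1c(Cc2ccc(-c3ccccc3)cc2)c(=O)oc2cc(OCC(O)CN3CCC(C(N)=O)CC3)ccc12` differs from compound 3 by phenyl in place of bromo on an aromatic carbon. Going by the values given here, no measured step touches this position, and the limit of > 100000 nM in this assay, at which 2 of the 3 values shown sit, leaves little room to resolve a change on this side of the molecule. The step expected from this change is an at least 1.1-fold lower number from compound 3 to compound 4 (0.04 log units; that floor lies within the scatter). The estimate for compound 4 is 90000 nM, with a range from 30000 nM to 200000 nM.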

Compound 4, half-maximal cytotoxic concentration: > 100000 nM
Compound 4 ended at the assay's limit; the forecaster's own chance of this, stated with the estimate: 55%; middle value at least 1.1-fold (0.04 log units) away from the limit.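

No step can be read between compound 3 and compound 4, as both rest at a limit rather than a number: the limit of > 100000 nM in this assay, at which 3 of the 4 values shown sit.

The compounds shown leave open whether phenyl in place of bromo on an aromatic carbon changes the cytotoxicity read-out at all.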